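A few compounds are considered here, and "the series" means these few. Any claim that something is new, unique, unknown or untested is made for them only; others in the source may bear on it.

Compound 1 `C[C@@H]1CN([C@@H](C)CO)C(=O)c2cccc(NC(=O)N(C)c3cccc4ccccc34)c2O[C@H]1CN(C)S(=O)(=O)c1ccc2c(c1)OCCO2` — 11200 nM
Compound 2 `C[C@@H]1CN([C@@H](C)CO)C(=O)c2cccc(NC(=O)Nc3cccc4ncccc34)c2O[C@H]1CN(C)S(=O)(=O)c1ccc2c(c1)OCCO2` — 139000 nM

In a physicochemical assay for solubility, read by HPLC, in phosphate buffer, measured as thermodynamic solubility, with a stated time of 24 h, at pH 7.4 (on this read-out lower numbers stand for lower solubility and higher numbers for higher solubility), compound 1 gives 11200 nM, and compound 2 gives 139000 nM. Going by the values given here, the single measured step, a 12-fold higher number from compound 1 to compound 2 (1.09 log units; beyond the scatter), leaves compound 2 with the higher of the two numbers. Compound 3 `C[C@@H]1CN([C@@H](C)CO)C(=O)c2cccc(NC(=O)Nc3cccc4cccnc34)c2O[C@H]1CN(C)S(=O)(=O)c1ccc2c(c1)OCCO2` is not yet measured; it differs from compound 2 in quinolin-8-yl in place of quinolin-5-yl on an amide-type nitrogen. Among the compounds with values here, no measured step covers an exchange of quinolin-5-yl for quinolin-8-yl: the one step known, a 12-fold higher number from compound 1 to compound 2 (1.09 log units; beyond the scatter), alters both the methyl on the amide-type nitrogen and the aromatic group at once, and so bears on the present step only loosely. With nothing pointing in a particular direction, no shift beyond the scatter is expected in this assay, and a 1.3-fold lower number from compound 2 to compound 3 (0.10 log units; within the scatter) is the estimated step. Compound 3 is therefore expected to give about 110000 nM, within a range from 35000 nM to 350000 nM.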

Compound 3, solubility: 1800 nM
Beside the measured number, compound 3's estimate is 61-fold (1.79 log units) above it, and the stated range ends above it.
By their numbers in this assay, from the lowest: compound 3; then compound 1; then compound 2.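

In this assay, the exchange of quinolin-5-yl for quinolin-8-yl on an amide-type nitrogen, two groups with the same atoms joined differently, comes with a 77-fold lower number from compound 2 to compound 3 (1.89 log units; beyond the scatter), so at this position the point of attachment alone goes with a large step. Replacing methyl(naphthalen-1-yl)amino on a carbonyl carbon with (quinolin-8-yl)amino comes with a 6.2-fold lower number from compound 1 to compound 3 (0.79 log units; beyond the scatter), so the direction of that replacement in this read-out depends on which quinolinyl group enters, something the earlier pair could not show. No measured evidence accompanying these compounds speaks to the origin of the step.

The compounds shown leave open how much of the earlier step goes with the methyl alone, which a methyl(quinolin-5-yl)amino group on the carbonyl carbon would separate. They also leave open where quinolin-6-yl on the amide-type nitrogen would fall.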